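Trimming the amide substituent toward a bare methyl

The source may report more compounds than this note shows. Statements on the series, on what has been measured and on what is new or still open speak of the compounds shown alone.

Compound 3 `CCN(CC)S(=O)(=O)c1ccc(S(=O)(=O)N2CCC[C@@H](C(=O)NC3COC3)C2)cc1` stands lowest of the two numbers given: in a functional assay on MIA PaCa-2 cells (Homo sapiens) for inhibition, read by MTT assay, with a stated time of 3 days (a higher number here means a weaker inhibitor, a lower number a stronger inhibitor), compound 3 gives 900 nM. Compound 1 `CCN(CC)S(=O)(=O)c1ccc(S(=O)(=O)N2CCC[C@@H](C(=O)NC3CN(C(=O)C4CC4)C3)C2)cc1` gives 3100 nM in this assay, and the step is a 3.4-fold lower number from compound 1 to compound 3 (0.54 log units; beyond the scatter). Compound 2 `CCN1CC(NC(=O)[C@@H]2CCCN(S(=O)(=O)c3ccc(S(=O)(=O)N(CC)CC)cc3)C2)C1` reaches only a limit in this assay, namely > 10000 nM. Compound 2 thus sits at the limit of > 10000 nM in this assay, at which 1 of the 3 values shown sits. The steps of an at least 3.2-fold higher number from compound 1 to compound 2 (0.50 log units; beyond the scatter) and an at least 11-fold lower number from compound 2 to compound 3 (1.04 log units; beyond the scatter) show that what sits on this amide nitrogen moves the number. Compound 4 `CCN(CC)S(=O)(=O)c1ccc(S(=O)(=O)N2CCC[C@@H](C(=O)NC)C2)cc1` carries the change (methyl in place of oxetan-3-yl on an amide-type nitrogen). Both measured steps toward compound 3 went toward lower numbers as the group shrank, but none of them reaches a single-carbon group, so the expectation for compound 4 is a step of a 1.7-fold higher number from compound 3 to compound 4 (0.22 log units; within the scatter), near the scatter. Compound 4 is expected at 1500 nM, between 400 nM and 6000 nM.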

Compound 4, half-maximal inhibitory concentration: 2000 nM
Beside the measured number, compound 4's estimate is 1.3-fold (0.12 log units) below it; measured number inside the range.
By their numbers in this assay, from the lowest: compound 3; then compounds 4 and 1 (each within the scatter of the next). At a limit, above all of these: compound 2.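

Shrinking the group on the amide-type nitrogen does not keep lowering the number: going from oxetan-3-yl to methyl gives a 2.2-fold higher number from compound 3 to compound 4 (0.35 log units; beyond the scatter). Against 1-(cyclopropylcarbonyl)azetidin-3-yl, methyl gives a 1.6-fold lower number from compound 1 to compound 4 (0.19 log units; within the scatter), so these two groups cannot be told apart despite their difference in size. Against 1-ethylazetidin-3-yl, methyl gives an at least 5.0-fold lower number from compound 2 to compound 4 (0.69 log units; beyond the scatter), a step that starts from a limit: the limit of > 10000 nM in this assay, at which 1 of the 4 values shown sits.

From the compounds shown here alone, it remains open whether the lowest number goes with the four-membered ring or with its oxygen. A cyclobutyl group or a 2-methoxyethyl chain on this nitrogen would separate the two.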